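The compounds below may be only part of what the source reports. "The series", "measured", "known", "first", "only" and "open" are said of these compounds alone.

Measured so far in an assay on isolated protein for inhibition of malate dehydrogenase, mitochondrial (Sus scrofa), with stated times of 45 min and 30 min; a higher number here means a weaker inhibitor, a lower number a stronger inhibitor:
compound 1 `O=S(=O)(Nc1ccc(-c2nc3ccccc3o2)cc1)c1ccc(Cl)s1`: > 63000 nM
compound 2 `COc1cccc(S(=O)(=O)Nc2ccc3oc(-c4ccccc4)nc3c2)c1`: > 63000 nM
compound 3 `O=[N+]([O-])c1cc(S(=O)(=O)Nc2ccc(-c3nc4ccccc4o3)cc2)ccc1Cl`: > 63000 nM

Each of these three values is a limit of the assay and not a number. The whole set sits at one place: the limit of > 63000 nM in this assay, at which 3 of the 3 values shown sit. Compound 2 therefore stands with the rest, holding only a limit in this assay, and no order among compounds 1, 2 and 3 can be read from these entries.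

Compound 4 `CCc1ccc(S(=O)(=O)Nc2ccc3oc(-c4ccccc4)nc3c2)cc1` is not yet measured. It differs from compound 2 in one place: 4-ethylphenyl in place of 3-methoxyphenyl on a sulfonyl sulfur. Among the compounds with values here, no step between measured compounds exists to calibrate this change, and nothing in the set shows measurable inhibition in this assay. The step expected is none beyond the scatter: a step that the limit leaves unreadable from compound 2 to compound 4. The most likely outcome for compound 4 is another limit rather than a number. Compound 4 is expected to give about 100000 nM in this assay, with a range from 40000 nM to 250000 nM.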

Compound 4, half-maximal inhibitory concentration: > 63000 nM
Compound 4 was reported as a limit; the forecaster's own chance of this, stated with the estimate: 85%; the middle value does not contradict the limit.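

In this assay, within the data shown here, no step from compound 2 to compound 4 can be read, because both entries are limits and not numbers: the limit of > 63000 nM in this assay, at which 4 of the 4 values shown sit. The compounds shown leave open whether 4-ethylphenyl and 3-methoxyphenyl on a sulfonyl sulfur differ at all, and whether any compound here gives a measurable inhibition in this assay.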